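Tertiary alcohol variants on the triazole arm

The source may report more compounds than this note shows. Statements on the series, on what has been measured and on what is new or still open speak of the compounds shown alone.

Measured so far:
compound 1 `CC(C)(C)c1cn(CCNc2nonc2/C(=N/O)Nc2ccc(F)c(Br)c2)nn1` gives 1870 nM
compound 2 `CC(C)(O)c1cn(CCNc2nonc2/C(=N/O)Nc2ccc(F)c(Br)c2)nn1` gives 726 nM
compound 3 `CCC(C)(O)c1cn(CCNc2nonc2/C(=N/O)Nc2ccc(F)c(Br)c2)nn1` gives 958 nM

In an assay on isolated protein for inhibition of Indoleamine 2,3-dioxygenase 2 (Homo sapiens) (on this read-out lower numbers stand for stronger inhibition and higher numbers for weaker inhibition), compound 3 stands second highest of the three numbers; its nearest neighbour is compound 2 with a 1.3-fold higher number from compound 2 to compound 3 (0.12 log units; within the scatter), its furthest compound 1 with a 2.0-fold lower number from compound 1 to compound 3 (0.29 log units; within the scatter), both within the scatter. Compound 4 `O/N=C(\Nc1ccc(F)c(Br)c1)c1nonc1NCCn1cc(C2(O)CCCCC2)nn1` carries 1-hydroxycyclohexyl in place of 1-hydroxy-1-methylpropyl on an aromatic carbon. Going by the values given here, the steps that bear on this change are a 1.3-fold higher number from compound 2 to compound 3 (0.12 log units; within the scatter) and a 2.0-fold lower number from compound 1 to compound 3 (0.29 log units; within the scatter), both within the scatter, whereas a 2.6-fold lower number from compound 1 to compound 2 (0.41 log units; beyond the scatter) was modest. Changes of this kind have so far moved this assay little, so for compound 4 the step of a 1.0-fold higher number from compound 3 to compound 4 (0.02 log units; within the scatter) is expected to stay within the scatter. Compound 4 is therefore estimated at 1000 nM, with a range from 400 nM to 2500 nM.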

Compound 4, half-maximal inhibitory concentration: 865 nM
Estimate against measurement, compound 4: 1.2-fold (0.06 log units) above; the range from low to high includes it.
By their numbers in this assay, from the lowest: compounds 2, 4, 3 and 1 (each within the scatter of the next, the first and the last beyond it).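

In this assay, the 1-hydroxycyclohexyl ring, the first ring at this position, reads the same as the open-chain tertiary alcohols (a 1.1-fold lower number from compound 3 to compound 4 (0.04 log units; within the scatter); a 1.2-fold higher number from compound 2 to compound 4 (0.08 log units; within the scatter)). Against the tert-butyl group, the ring gives a modest step beyond the scatter (a 2.2-fold lower number from compound 1 to compound 4 (0.33 log units; beyond the scatter)), as compound 2 does, while compound 3 stays within the scatter of compound 1. No measured evidence accounts for these readings.

The compounds shown leave open how far ring size can vary at this position. They also leave open how an amine or a carboxylic acid would read in place of the hydroxy.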